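Swapping 4-ethoxyphenyl for 3-chlorophenyl in an inactive series

This account rests on a few compounds, and the source may have more. Where it says the series, first, only, none or still open, it means among the compounds named here.

Values from a functional assay on SEM cells (Homo sapiens) for cytotoxicity, with a stated time of 72 h (on this read-out higher numbers stand for an effect only at larger amounts of compound and lower numbers for an effect already at smaller amounts), follow, each one a limit and not a number.

Compound 1 `C=C[C@@](C)(/C=C/c1ccc(O)c(/C=C/C(N)=O)c1)CCC=C(C)C` gives > 36600 nM as a limit.
Compound 2 `COc1ccc(/C=C/[C@@](C)(/C=C/c2ccc(O)c(/C=C/C(=O)OCc3ccccc3)c2)CCC=C(C)C)cc1` gives > 36600 nM as a limit.
Compound 3 `CCOc1ccc(/C=C/[C@@](C)(/C=C/c2ccc(O)cc2)CCC=C(C)C)cc1` gives > 36600 nM as a limit.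

Compound 3 stands at the limit of > 36600 nM in this assay, at which 3 of the 3 values shown sit, and so offers a bound rather than a number to measure from. Among the compounds with values here, no step between measured compounds that differ in one place is available, so the expectation rests on this shared limit and on the structural change alone.

Compound 4 `CC(C)=CCC[C@](C)(/C=C/c1ccc(O)cc1)/C=C/c1cccc(Cl)c1` carries 3-chlorophenyl in place of 4-ethoxyphenyl on a double-bonded chain carbon bound to a double-bonded chain carbon, as counted in 3-chlorophenyl in place of 4-ethoxyphenyl on a double-bonded chain carbon bound to a double-bonded chain carbon here. In this assay no step beyond the scatter is firmly expected, and any shift would run toward lower numbers. The estimated change is an at least 1.2-fold lower number from compound 3 to compound 4 (0.08 log units; that floor lies within the scatter) and it is expected to be small. For compound 4 the estimate is 30000 nM with an expected range from 10000 nM to 60000 nM and another report of only a limit is quite likely.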

Compound 4, half-maximal effective concentration: > 36600 nM
Compound 4 ended at the assay's limit; the forecaster's own chance of this, stated with the estimate: 65%; at least 1.2-fold (0.08 log units) between middle value and limit.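

Within the data shown here, compound 3 and compound 4 both end at a limit in this assay and no step between them can be read: the limit of > 36600 nM in this assay, at which 4 of the 4 values shown sit.

The compounds shown leave open whether any member of this series reaches a readable value in this assay and how 3-chlorophenyl compares with 4-ethoxyphenyl.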